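Octylsulfanyl in place of cyclopentylamino: cytotoxicity notes

A few compounds are considered here, and "the series" means these few. Any claim that something is new, unique, unknown or untested is made for them only; others in the source may bear on it.

Within the data shown here, in an ADME assay on BCBL1 cells (Homo sapiens) for cytotoxicity, with a stated time of 7 days (on this read-out higher numbers stand for lower toxicity in this test and lower numbers for higher toxicity in this test), compound 3 (`Nc1nc(NC2CCCC2)c2ncn(/C=C3/CC3(CO)CO)c2n1`) gives 71700 nM, the only actual number among the three measured compounds.

Compound 1 (`CCCCCCCCOc1nc(N)nc2c1ncn2/C=C1/CC1(CO)CO`) gives > 20000 nM, which is a limit of the assay.

Compound 2 (`CCCNc1nc(N)nc2c1ncn2/C=C1/CC1(CO)CO`) gives > 20000 nM, which is also a limit.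

Compound 4 (`CCCCCCCCSc1nc(N)nc2c1ncn2/C=C1/CC1(CO)CO`) carries octylsulfanyl in place of cyclopentylamino on an aromatic carbon.

Among the measured compounds shown here, three measured steps bear on this change, and none has a readable size. The closest is a step that the limit leaves unreadable from compound 1 to compound 3, which links cyclopentylamino to octyloxy. The other two are a step that the two limits leave unreadable from compound 1 to compound 2 and a step that the limit leaves unreadable from compound 2 to compound 3. The direction therefore stays weakly founded because of the limit of > 20000 nM in this assay, at which 2 of the 3 values shown sit.

With no measured size to carry over, a moderate fall in this assay is the working expectation, meaning somewhat higher toxicity in this test, though a result within the scatter of compound 3 would not surprise. The expected change is a 1.8-fold lower number from compound 3 to compound 4 (0.25 log units; within the scatter).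

The estimate for compound 4 is 40000 nM, with an expected range of 15000 nM to 100000 nM.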

Compound 4, half-maximal cytotoxic concentration: > 20000 nM
Compound 4 was reported as a limit; the forecaster's own chance of this, stated with the estimate: 50%; the middle value lies beyond the limit too.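

In this assay none of the steps from compound 1, compound 2 or compound 3 to compound 4 can be read, for one reason: the limit of > 20000 nM in this assay, at which 3 of the 4 values shown sit.

In this assay the compounds shown leave open how far octylsulfanyl, octyloxy, propylamino and cyclopentylamino differ on the shared core.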